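The compounds below may be only part of what the source reports. "The series", "measured", "known", "first", "only" and "open" are said of these compounds alone.

In a functional assay on HT-29 cells (Homo sapiens) for inhibition, read by sulforhodamine B assay, with a stated time of 48 h (on this read-out higher numbers stand for weaker inhibition of growth and lower numbers for stronger inhibition of growth), compound 1 `CCOC(=O)c1nn(-c2ccccc2)c(-c2ccccc2)c1CNC(C)(C)C` gives 69600 nM; 94600 nM (2 entries), and compound 2 `CC(C)(C)NCc1c(C(=O)O)nn(-c2ccccc2)c1-c1ccc(Cl)cc1` gives 353000 nM. For compound 3 `CC(C)(C)NCc1c(C(=O)O)nn(-c2ccccc2)c1-c1ccc(Br)cc1` only a limit is known, > 585000 nM. Compound 4 `CC(C)(C)NCc1c(C(=O)O)nn(-c2ccccc2)c1-c1ccccc1` differs from it by one change, hydrogen in place of bromo on an aromatic carbon. The closest measured change is bromo in place of chloro on an aromatic carbon, which gave an at least 1.6-fold higher number from compound 2 to compound 3 (0.21 log units; that floor lies within the scatter). That step is small and open-ended, so it offers only weak guidance. In this assay, a modest move toward lower numbers is therefore expected, leaving compound 4 in the region of compound 2 at 353000 nM. The expected change is an at least 1.3-fold lower number from compound 3 to compound 4 (0.14 log units; that floor lies within the scatter). The estimate for compound 4 is 420000 nM, with an expected range of 170000 nM to 900000 nM.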

Compound 4, concentration for 50% growth inhibition: > 716000 nM
Compound 4 was reported as a limit; the forecaster's own chance of this, stated with the estimate: 30%; at least 1.7-fold (0.23 log units) between middle value and limit.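

Compound 4 is reported only as a limit: the limit of > 716000 nM in this assay, at which 1 of the 4 values shown sits. Compound 3 is also a limit, so the step between these two cannot be read, and removing the bromo from this place gives no readable move toward stronger inhibition of growth. Hydrogen in place of chloro gives an at least 2.0-fold higher number from compound 2 to compound 4 (0.30 log units; that floor lies within the scatter), so at this place the plain phenyl shows no gain over the halogen-bearing ring.

Still open, on these data alone, is how a methoxy group or an amine at this same place would behave, and whether either would give a lower number in this assay.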